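A few compounds are considered here, and "the series" means these few. Any claim that something is new, unique, unknown or untested is made for them only; others in the source may bear on it.

Going by the values given here, in a functional assay on A549 cells (Homo sapiens) for antiproliferative activity, read by MTT assay, with a stated time of 72 h (a higher number here means a weaker inhibitor, a lower number a stronger inhibitor), compound 2 `COc1cc2ncnc(Nc3ccc(Br)cc3F)c2cc1OCCCN1CCNCCNCC1` gives 16100 nM, the highest of the three numbers so far. Among the compounds with values here, compound 1 `COc1cc2ncnc(Nc3ccc(Br)cc3F)c2cc1OCCCN1CCNCCNCCNCC1` gives 15200 nM, and the step of a 1.1-fold higher number from compound 1 to compound 2 (0.02 log units; within the scatter) is the only single-place step measured. Within the data shown here, compound 3 `COc1cc2ncnc(Nc3ccc(OCc4cccc(F)c4)c(Cl)c3)c2cc1OCCCN1CCNCCNCC1` gives 7250 nM, the furthest from compound 2 and beyond the scatter, but no single-place step links the two. Compound 4 `COc1cc2ncnc(Nc3ccc(C#N)cc3F)c2cc1OCCCN1CCNCCNCC1` differs from compound 2 in one place: cyano in place of bromo on an aromatic carbon. Among the measured compounds shown here, no measured step touches this change; the one step available concerns a different part of the molecule. No movement beyond the scatter is therefore expected. The expected step is a 1.2-fold lower number from compound 2 to compound 4 (0.06 log units; within the scatter), essentially flat. Compound 4 is estimated at 14000 nM, within a range from 5500 nM to 36000 nM.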

Compound 4, half-maximal inhibitory concentration: > 50000 nM
Compound 4: no number, only a limit (the forecaster's own chance of this, stated with the estimate: 5%); middle value at least 3.5-fold (0.55 log units) away from the limit.
By their numbers in this assay, from the lowest: compound 3; then compounds 1 and 2 (each within the scatter of the next). At a limit, above all of these: compound 4.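

In this assay, cyano in place of bromo gives an at least 3.1-fold higher number from compound 2 to compound 4 (0.49 log units; beyond the scatter), so this position, para to a large group, responds to a change, whereas the earlier single-place step, on the saturated chain, stayed within the scatter. Compound 4 is read only at a limit, so the step gives a minimum size and no more: the limit of > 50000 nM in this assay, at which 1 of the 4 values shown sits.

As far as these compounds go, whether this reflects cyano itself or the departure of bromo stays open, and a methyl or methoxy group at this place would help to separate the two. From the compounds shown here alone, how the same change behaves with the larger ring of compound 1 also stays open.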